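Urea-linked pyrazole series: removal of one trifluoromethyl

The compounds below may be only part of what the source reports. "The series", "measured", "known", "first", "only" and "open" are said of these compounds alone.

Measured so far:
compound 1 `O=C(Nc1cccc(-n2cc(-c3ccncc3)c(-c3cc(O)cc(Cl)c3)n2)c1)Nc1ccc(Cl)c(Cl)c1` -10%
compound 2 `COc1cc(Cl)cc(-c2nn(-c3cccc(NC(=O)Nc4ccc(Cl)c(C(F)(F)F)c4)c3)cc2-c2ccncc2)c1` -28%
compound 3 `COc1cc(Cl)cc(-c2nn(-c3cccc(NC(=O)Nc4cc(C(F)(F)F)cc(C(F)(F)F)c4)c3)cc2-c2ccncc2)c1` -34%

All three share one core and differ in the substituents on the aryl urea and on the pendant phenyl. In a functional assay on MOLT-4 cells (Homo sapiens) for inhibition, read by sulforhodamine B assay, with a stated time of 48 h, tested at 100 uM (a higher number here means a weaker effect of the compound at the concentration tested, a lower number a stronger effect), compound 3 gives -34%, the lowest of the three numbers. Compound 2 gives -28% in this assay, a number within the scatter of compound 3, so no order between compound 2 and compound 3 can be read. Compound 1 gives -10% in this assay, a number beyond the scatter away from compound 3 in the direction of weaker effect.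

Compound 4 `COc1cc(Cl)cc(-c2nn(-c3cccc(NC(=O)Nc4cccc(C(F)(F)F)c4)c3)cc2-c2ccncc2)c1` is the next compound, not yet measured in this assay. It differs from compound 3 in one place: hydrogen in place of trifluoromethyl on an aromatic carbon. The second trifluoromethyl group on the urea aryl is kept.

Among the compounds with values here, no step between two measured compounds matches this change, so its size is not known from the numbers in hand. Given that compound 2 and compound 3 sit within the scatter of each other despite different substituents on that ring, the step from compound 3 to compound 4 is expected to be small, at most a modest shift toward higher numbers, a number 8 percentage points higher from compound 3 to compound 4 (within the scatter). Compound 4 is therefore estimated at -26%, with a range from -46% to -6%.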

Compound 4, a percentage reported as activity, at one concentration (the size of the read-out at that concentration, not a potency): -36%
Compound 4: middle estimate off by 10 percentage points, on the high side; measured number inside the range.
By their numbers in this assay, from the lowest: compounds 4, 3 and 2 (each within the scatter of the next); then compound 1.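

In this assay, the first exchange read directly at this aromatic carbon, hydrogen in place of trifluoromethyl, gives a number 2 percentage points lower from compound 3 to compound 4 (within the scatter), so the read-out does not separate the two groups at this place on the urea aryl ring, meta to a trifluoromethyl group. The exchange of hydrogen for chloro on an aromatic carbon gives a number 8 percentage points lower from compound 2 to compound 4 (within the scatter), so that ring also shows no separable shift when its chloro is replaced, and three substitution patterns on it now sit together at this single concentration. No measured data on the compounds bear on why these exchanges leave the number within the scatter.

Since every step read so far at this ring lies within the scatter, the compounds shown leave open whether any group at this aromatic carbon can move the number beyond it, for instance an amine, a carboxylic acid or a longer chain such as an n-butyl group. They also leave open what happens when the remaining trifluoromethyl of compound 4 is exchanged for hydrogen, and whether the same flatness would hold as a potency rather than as a read-out at one concentration.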